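Removing a Methoxy Group from a Triazole-Bearing Core

The source may report more compounds than this note shows. Statements on the series, on what has been measured and on what is new or still open speak of the compounds shown alone.

Compound 1 `Cc1c(O)ccc2c1[C@H](Cn1cc(-c3ccc(F)cc3)nn1)[C@@]13CC(=O)[C@@](C)(CC[C@@H]21)C3` gives > 20000 nM in a functional assay on SMMC-7721 cells (Homo sapiens) for cytotoxicity, read by MTT assay, with a stated time of 4 days (on this read-out higher numbers stand for weaker inhibition and lower numbers for stronger inhibition), and this value is a limit of the assay rather than a number.
Compound 2 `C=C1C[C@]23C[C@@]1(O)CC[C@H]2c1ccc(O)c(C)c1[C@@H]3Cn1cc(-c2ccc(C(F)(F)F)cc2)nn1` gives > 20000 nM in this assay, again a limit rather than a number.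
Compound 3 `C=C1C[C@]23C[C@@]1(O)CC[C@H]2c1cc(Br)c(O)c(C)c1[C@@H]3Cn1cc(-c2ccc(OC)cc2)nn1` gives > 20000 nM in this assay, also a limit rather than a number.

Compound 3 therefore stands exactly where the rest of this small set stands: at the limit of > 20000 nM in this assay, at which 3 of the 3 values shown sit. Nothing measured here separates compound 3 from compound 1 or compound 2, and none of the three can be called stronger or weaker than another.

Compound 4 `C=C1C[C@]23C[C@@]1(O)CC[C@H]2c1cc(Br)c(O)c(C)c1[C@@H]3Cn1cc(-c2ccccc2)nn1` differs from compound 3 in a single place: hydrogen in place of methoxy on an aromatic carbon. Going by the values given here, no pair of measured compounds shows what this change does in this assay, so the expectation rests only on where compound 3 and its companions sit. Because all three values sit at the limit of > 20000 nM in this assay, at which 3 of the 3 values shown sit, the expected step is a step that the limit leaves unreadable from compound 3 to compound 4, which is to say none beyond the scatter. Compound 4 is accordingly expected to give about 25000 nM, within a range from 8000 nM to 60000 nM, and most probably the assay will again report only a limit rather than a number.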

Compound 4, half-maximal inhibitory concentration: > 20000 nM
Compound 4 was reported as a limit; the forecaster's own chance of this, stated with the estimate: 85%; the middle value is on the limit's open side.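

Going by these compounds alone, compound 3 and compound 4 are both reported as limits rather than numbers in this assay, so no step between them can be read. The compounds shown leave open whether hydrogen in place of methoxy changes anything in this assay, as all sit together: the limit of > 20000 nM in this assay, at which 4 of the 4 values shown sit.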